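The source may report more compounds than this note shows. Statements on the series, on what has been measured and on what is new or still open speak of the compounds shown alone.

For the measured compounds named here, compound 2 `CNC(=O)c1ccccc1Oc1nc(Nc2cccc(C(F)(F)F)c2)ncc1Br` is one of only two compounds measured in a functional assay on HL-60 cells (Homo sapiens) for antiproliferative activity, read by MTT assay, with a stated time of 24 h (a higher number here means a weaker inhibitor, a lower number a stronger inhibitor), where compound 2 gives 44000 nM. The other measured compound, compound 1 `CNC(=O)c1ccccc1Oc1nc(Nc2ccc(C)cc2C)ncc1Br`, gives 32300 nM in this assay; the two numbers lie within the usual scatter of each other, so neither compound can be said to stand apart from the other. Compound 3 `CNC(=O)c1ccccc1Oc1nc(Nc2cccc(OC)c2)ncc1Br` has not yet been measured. It differs from compound 2 in a single place: methoxy in place of trifluoromethyl on an aromatic carbon. Going by the values given here, no measured pair shows what this kind of change does here, so there is no earlier step to lean on. Among the compounds with values here, with both measured compounds giving weak inhibition and only one group exchanged, the expected step of a 1.2-fold lower number from compound 2 to compound 3 (0.06 log units; within the scatter) in this assay is none beyond the scatter. For compound 3 the estimate in this assay is therefore 38000 nM, with a likely range from 12000 nM to 110000 nM.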

Compound 3, half-maximal inhibitory concentration: 16200 nM
Compound 3: middle estimate off by 2.3-fold (0.37 log units), on the high side; the range from low to high includes it.
By their numbers in this assay, from the lowest: compounds 3, 1 and 2 (each within the scatter of the next, the first and the last beyond it).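

In this assay, putting methoxy in place of trifluoromethyl on this aromatic carbon gives a 2.7-fold lower number from compound 2 to compound 3 (0.43 log units; beyond the scatter) and is the only change shown that moves the number beyond the scatter, so the group held here does matter, if only modestly. Putting 3-methoxyphenyl in place of 2,4-dimethylphenyl on the nitrogen gives a 2.0-fold lower number from compound 1 to compound 3 (0.30 log units; within the scatter) and so does not separate compound 3 from compound 1, which means compound 3 stands clear of compound 2 alone. Nothing available explains why the number moves with this exchange.

The compounds shown leave open whether another group on this aromatic carbon, such as an amine, a carboxylic acid or a longer ether chain, would lower the number further. They also leave open whether the methoxy step would hold with a different group in place of the bromine on the core.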